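Swapping a Hydroxymethyl Ethyl Amide Cap for a Cyclopropyl

The source may hold more compounds than are shown below. What is called first, only, known or untested is meant among the compounds shown, and "the series" means these compounds.

Of the compounds shown here, three built on one shared core have been tested in a functional assay on PC-3 cells (Homo sapiens) for antiproliferative activity, read by MTT assay, with a stated time of 24 h; a lower number here means a stronger inhibitor, a higher number a weaker inhibitor. Compound 1 `CCn1c(C(=O)NCCNC(=O)OC(C)(C)C)ccc1C(CC)(CC)c1ccc(OCS(=O)(=O)c2ccccc2)c(C)c1` gives only a limit there, > 50000 nM. Compound 2 `CCn1c(C(=O)NCCN)ccc1C(CC)(CC)c1ccc(OCS(=O)(=O)c2ccccc2)c(C)c1` gives 6890 nM, and compound 3 `CCn1c(C(=O)N[C@@H](C)CO)ccc1C(CC)(CC)c1ccc(OCS(=O)(=O)c2ccccc2)c(C)c1` gives 9520 nM. The steps of an at least 7.2-fold lower number from compound 1 to compound 2 (0.86 log units; beyond the scatter) and an at least 5.2-fold lower number from compound 1 to compound 3 (0.72 log units; beyond the scatter) are both at least modest. Compound 3 stands alongside compound 2, the two numbers not separable by the scatter, as a 1.4-fold higher number from compound 2 to compound 3 (0.14 log units; within the scatter) shows. Compound 4 `CCn1c(C(=O)NC2(CO)CC2)ccc1C(CC)(CC)c1ccc(OCS(=O)(=O)c2ccccc2)c(C)c1` differs from compound 3 by 1-(hydroxymethyl)cyclopropyl in place of 1-(hydroxymethyl)ethyl on an amide-type nitrogen. Among the measured compounds shown here, the only measured step that bears on this change, the one from compound 2 to compound 3, exchanged one small amide cap for another and stayed within scatter, so no step beyond the scatter is expected: a 1.1-fold lower number from compound 3 to compound 4 (0.02 log units; within the scatter). Compound 4 is therefore estimated at 9000 nM, between 3000 nM and 30000 nM.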

Compound 4, half-maximal inhibitory concentration: 3560 nM
Estimate against measurement, compound 4: 2.5-fold (0.40 log units) above; the range from low to high includes it.
By their numbers in this assay, from the lowest: compounds 4, 2 and 3 (each within the scatter of the next, the first and the last beyond it). At a limit, above all of these: compound 1.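

At the amide-type nitrogen, a small change in the cap is enough to move the number beyond the scatter when 1-(hydroxymethyl)cyclopropyl replaces 1-(hydroxymethyl)ethyl: a 2.7-fold lower number from compound 3 to compound 4 (0.43 log units; beyond the scatter). Against the 2-aminoethyl cap, the new cap stays within the scatter, a 1.9-fold lower number from compound 2 to compound 4 (0.29 log units; within the scatter), so compound 2 and compound 4 cannot be ordered. The largest step, an at least 14-fold lower number from compound 1 to compound 4 (1.14 log units; beyond the scatter), starts from a limit and not a number: the limit of > 50000 nM in this assay, at which 1 of the 4 values shown sits.

The compounds shown leave open whether the ring works without its hydroxyl group, as a plain cyclopropyl cap would show. They also leave open whether a larger ring, such as 1-(hydroxymethyl)cyclobutyl, or an amine in place of the hydroxyl, as in 1-(aminomethyl)cyclopropyl, would change the number.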